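A few compounds are considered here, and "the series" means these few. Any claim that something is new, unique, unknown or untested is made for them only; others in the source may bear on it.

In a functional assay on MCF7 cells (Homo sapiens) for cytotoxicity, read by MTT assay, with a stated time of 24 h; on this read-out lower numbers stand for stronger inhibition and higher numbers for weaker inhibition:
- compound 1 `COc1ccc(Nc2ncnc3cc(OC)c(OCCCSc4nc5ccccc5s4)cc23)cc1`: 14200 nM
- compound 2 `CCCCc1nc(Cl)c(C=O)n1CCCOc1cc2c(Nc3ccc(F)c(Cl)c3)ncnc2cc1OC`: 5020 nM
- compound 3 `CCCCc1nc(Cl)c(C=O)n1CCCOc1cc2c(Nc3ccc(OC)cc3)ncnc2cc1OC`: 14000 nM

Compound 3 belongs to the upper pair of these numbers, as the data show a 1.0-fold lower number from compound 1 to compound 3 (0.01 log units; within the scatter). Compound 4 `CCCCc1nc(Cl)c(C=O)n1CCCOc1cc2c(Nc3cccc(F)c3)ncnc2cc1OC` carries 3-fluorophenyl in place of 4-methoxyphenyl on a nitrogen on an aromatic ring.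

Within the data shown here, only one measured step changes this place, and it shows a 2.8-fold higher number from compound 2 to compound 3 (0.45 log units; beyond the scatter). The other step changes a different place and does not bear on this one. Like compound 2, compound 4 lacks 4-methoxyphenyl, but a single modest step is thin evidence. The expected change is a 1.6-fold lower number from compound 3 to compound 4 (0.22 log units; within the scatter), a lower number in this assay that may not clear the scatter. For compound 4 the estimated value is 8500 nM, with an expected range of 3800 nM to 17000 nM.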

Compound 4, half-maximal inhibitory concentration: 12000 nM
Estimate against measurement, compound 4: 1.4-fold (0.15 log units) below; low and high end bracket the measured number.
By their numbers in this assay, from the lowest: compound 2; then compounds 4, 3 and 1 (each within the scatter of the next).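

In this assay, 3-fluorophenyl and 4-methoxyphenyl on the nitrogen cannot be told apart (a 1.2-fold lower number from compound 3 to compound 4 (0.07 log units; within the scatter)), so the step from compound 2 to compound 3 does not simply reflect the loss of 3-chloro-4-fluorophenyl in favour of any other group tested there. 3-Chloro-4-fluorophenyl now stands apart from both of these groups, including 3-fluorophenyl (a 2.4-fold higher number from compound 2 to compound 4 (0.38 log units; beyond the scatter)). No data at hand explain this difference.

Still open, on these data alone, is how 3-chlorophenyl or an aminophenyl group would read on this nitrogen. Also open, as far as these compounds go, is whether 3-chloro-4-fluorophenyl keeps its edge with the (1,3-benzothiazol-2-yl)sulfanyl chain of compound 1.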